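Metabolic stability across the aryl amine series

The source may report more compounds than this note shows. Statements on the series, on what has been measured and on what is new or still open speak of the compounds shown alone.

Measured so far:
- compound 1, `CNc1cc(Nc2cccc(-c3ccccc3)c2)nn2c(C(N)=O)cnc12`: 51%
- compound 2, `CNc1cc(Nc2cc(F)cc(F)c2OC)nn2c(C(=O)NC[C@](C)(O)CO)cnc12`: 99%

In an ADME assay on microsomes from liver (Homo sapiens) for metabolic stability, read by mass spectrometry, with a stated time of 10 min, tested at 0.5 uM (a higher number here means that more of the compound is left, a lower number that less of the compound is left), compound 2 gives 99%, the higher of the two numbers available. Compound 1 gives 51% in this assay, a gap that lies beyond the scatter of repeated runs. The two compounds differ in both the aryl amine and the amide, so no single change is isolated by this pair.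

Compound 3, `CNc1cc(Nc2c(F)c(F)cc(F)c2F)nn2c(C(=O)NC[C@](C)(O)CO)cnc12`, differs from compound 2 in one place: 2,3,5,6-tetrafluorophenyl in place of 3,5-difluoro-2-methoxyphenyl on a nitrogen on an aromatic ring. Within the data shown here, no measured pair shows this particular change, so nothing in the data fixes its size. Compound 2 sits near the top of what the read-out can report, so the step from it can hardly go upward; the expectation is a step from compound 2 to compound 3 of a number 7 percentage points lower from compound 2 to compound 3 (within the scatter) in this assay, small and not beyond the scatter. For compound 3 the estimate in this assay is 92%, with a range from 75% to 100%.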

Compound 3, percent of the compound remaining: 100%
Compound 3: the middle estimate sits 8 percentage points below what was measured; the range from low to high includes it.
By their numbers in this assay, from the lowest: compound 1; then compounds 2 and 3 (each within the scatter of the next).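

In this assay, among these compounds, 2,3,5,6-tetrafluorophenyl in place of 3,5-difluoro-2-methoxyphenyl on a nitrogen on an aromatic ring gives a step of [ a number 1 percentage points higher from compound 2 to compound 3 (within the scatter) ], the first comparison that isolates a change in one place. With the amide chain held constant, this position tolerates the exchange of the methoxy-bearing ring for a ring carrying only fluorine, with no loss that can be told from the scatter, although both compounds sit so close to the top of the read-out that any gain would be hidden. No supporting measurement bears on the reason for this outcome.

Compound 1 differs from both other compounds in the aryl amine and in the amide as well, so the share of each of those two places in its lower number stays unresolved. Also open, as far as these compounds go, is whether a pyridine ring or a phenyl ring bearing a carboxylic acid or an amine on the same nitrogen would hold the read-out at this level, and whether the same aryl exchanges would behave alike on the unsubstituted primary amide.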